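Widening the Amine Ring on a Shared Core

This account rests on a few compounds, and the source may have more. Where it says the series, first, only, none or still open, it means among the compounds named here.

Compound 1 `CC1CCN(c2ccc3cc(NC(=O)CCc4ccc(C(F)(F)F)cc4)ccc3n2)C1`: 400 nM
Compound 2 `O=C(CCc1ccc(C(F)(F)F)cc1)Nc1ccc2nc(N3CC4CCC3CC4)ccc2c1`: 190 nM

In a functional assay on HEK293 cells for activation of melanin-concentrating hormone receptor 1 (Rattus norvegicus), read by inositol phosphate accumulation (on this read-out lower numbers stand for an effect already at smaller amounts and higher numbers for an effect only at larger amounts of compound), compound 1 stands highest of the two numbers, and compound 2 is nearest, as the step of a 2.1-fold lower number from compound 1 to compound 2 (0.32 log units; beyond the scatter) shows. Compound 3 `O=C(CCc1ccc(C(F)(F)F)cc1)Nc1ccc2nc(N3CCCCCC3)ccc2c1` differs from compound 1 by azepan-1-yl in place of 3-methylpyrrolidin-1-yl on an aromatic carbon. Going by the values given here, the only measured step that bears on this, a 2.1-fold lower number from compound 1 to compound 2 (0.32 log units; beyond the scatter), also changes the ring group on this aromatic carbon and gives a modest lower number, so a step of similar size and direction is expected here. Compound 3 is therefore estimated at 250 nM, with a range from 100 nM to 700 nM. This means an expected step of a 1.6-fold lower number from compound 1 to compound 3 (0.20 log units; within the scatter).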

Compound 3, half-maximal effective concentration: 1800 nM
Compound 3: middle estimate off by 7.2-fold (0.86 log units), on the low side; measured number above the stated range.
By their numbers in this assay, from the lowest: compound 2; then compound 1; then compound 3.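

At this aromatic carbon, adding to the amine ring does not by itself lower the number in this assay: azepan-1-yl gives a 4.5-fold higher number from compound 1 to compound 3 (0.65 log units; beyond the scatter) and, set against the two-ring group, a 9.5-fold higher number from compound 2 to compound 3 (0.98 log units; beyond the scatter) in this series. The position therefore separates amine rings of nearly the same heavy-atom count, and the seven-membered ring stands highest of the three. Nothing available explains this difference. Still open, on these data alone, is where unsubstituted pyrrolidine or piperidine would fall, and whether a second ring nitrogen, as in piperazine, would move the number either way.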